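Trifluoromethylphenyl in place of chlorophenyl on the piperazine

The compounds below may be only part of what the source reports. "The series", "measured", "known", "first", "only" and "open" are said of these compounds alone.

Compound 1 `CCCc1nc(-c2ccccc2)c(CNCCN2CCN(c3ccccc3Cl)CC2)o1` gives 4370 nM in an assay on HEK293 cells for inhibition of Voltage-dependent T-type calcium channel subunit alpha-1G (Homo sapiens), read by patch clamp; a higher number here means a weaker inhibitor, a lower number a stronger inhibitor. Compound 3 `CCCc1nc(-c2ccccc2)c(CNCCCN2CCN(c3cccc(F)c3)CC2)o1` gives 3030 nM, and compound 1 and compound 3 lie within the scatter of one another. Compound 2 `CCCc1nc(-c2ccccc2)c(CNCCCN2CCN(c3cccc(C(F)(F)F)c3)CC2)o1` gives 650 nM, well clear of compound 1. Compound 4 `CCCc1nc(-c2ccccc2)c(CNCCN2CCN(c3ccc(C(F)(F)F)cc3)CC2)o1` carries 4-(trifluoromethyl)phenyl in place of 2-chlorophenyl on an amine nitrogen in a ring. Within the data shown here, no measured pair shows this exact change, but the step of a 4.7-fold higher number from compound 2 to compound 3 (0.67 log units; beyond the scatter) shows a trifluoromethyl on the aryl ring going with the lower number. On that basis compound 4 is expected to give a modestly lower number than compound 1, a step of a 2.9-fold lower number from compound 1 to compound 4 (0.46 log units; beyond the scatter). The estimate for compound 4 is 1500 nM, in the range 500 nM to 4500 nM.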

Compound 4, half-maximal inhibitory concentration: 1300 nM
The estimate for compound 4 lay 1.2-fold (0.06 log units) above the measured number; the measured number falls inside the stated range.
By their numbers in this assay, from the lowest: compounds 2 and 4 (each within the scatter of the next); then compounds 3 and 1 (each within the scatter of the next).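

In this assay the step is a 3.4-fold lower number from compound 1 to compound 4 (0.53 log units; beyond the scatter), which shows that 4-(trifluoromethyl)phenyl in place of 2-chlorophenyl on this amine nitrogen lowers the number on the chain of compound 1. The earlier step, a 4.7-fold higher number from compound 2 to compound 3 (0.67 log units; beyond the scatter), came from compounds with a different chain, so a trifluoromethyl-bearing aryl group now goes with the lower number on both chains. Nothing measured here gives a cause for this step.

As far as these compounds go, how 4-chlorophenyl would stand on this nitrogen remains open, so the change of group and the change of its place on the aryl ring cannot yet be told apart.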